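This account rests on a few compounds, and the source may have more. Where it says the series, first, only, none or still open, it means among the compounds named here.

Compound 3 `C#CCN1CCN(CC(=O)N2CCN(c3ccc(C(=O)c4cc5ccc(N(CC)CC)cc5o4)cc3)CC2)CC1` stands at a limit: in a functional assay on A549 cells (Homo sapiens) for cytotoxicity, read by MTT assay, with a stated time of 48 h (on this read-out lower numbers stand for stronger inhibition and higher numbers for weaker inhibition), compound 3 gives > 40000 nM, which is a limit of the assay and not a number. It shares that position with one other value, (the limit of > 40000 nM in this assay, at which 2 of the 3 values shown sit). For the measured compounds named here, compound 1 `CCN(CC)c1ccc2cc(C(=O)c3ccc(N4CCN(C(=O)CN5CCN(S(=O)(=O)C6CC6)CC5)CC4)cc3)oc2c1` is the only compound with a number; in this assay compound 1 gives 17300 nM. Compound 2 `CCN(CC)c1ccc2cc(C(=O)c3ccc(N4CCN(C(=O)CN5CCN(S(=O)(=O)c6ccc(C#N)cc6)CC5)CC4)cc3)oc2c1` is also at a limit; in this assay compound 2 gives > 40000 nM. The measured steps read an at least 2.3-fold higher number from compound 1 to compound 3 (0.36 log units; beyond the scatter) and an at least 2.3-fold higher number from compound 1 to compound 2 (0.36 log units; beyond the scatter), while a step that the two limits leave unreadable from compound 2 to compound 3.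

Compound 4 `CCN(CC)c1ccc2cc(C(=O)c3ccc(N4CCN(C(=O)CN5CCN(Cc6ccc(C#N)cc6)CC5)CC4)cc3)oc2c1` differs from compound 3 by 4-cyanophenyl in place of ethynyl on a saturated chain carbon bound to an amine nitrogen in a ring. Going by the values given here, the steps that bear on it are an at least 2.3-fold higher number from compound 1 to compound 2 (0.36 log units; beyond the scatter), where the same 4-cyanophenyl ring, there on a sulfonyl sulfur, went with a higher number, and the unreadable a step that the two limits leave unreadable from compound 2 to compound 3. With compound 3 already at a limit, no step beyond the scatter in either direction can be read for compound 4, and it is expected to stay at or past that limit. The expected step is a step that the limit leaves unreadable from compound 3 to compound 4. The estimate for compound 4 is 50000 nM, with a range from 20000 nM to 150000 nM.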

Compound 4, half-maximal inhibitory concentration: 17400 nM
Estimate against measurement, compound 4: 2.9-fold (0.46 log units) above; the measured number lies below the stated range.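

Putting 4-cyanophenyl in place of ethynyl on a saturated chain carbon bound to an amine nitrogen in a ring gave an at least 2.2-fold lower number from compound 3 to compound 4 (0.36 log units; beyond the scatter) in this assay, so this larger group does not push the value to the limit. The 4-cyanophenyl ring therefore does not by itself go with a higher number, since 4-cyanobenzyl in place of (4-cyanophenyl)sulfonyl gave an at least 2.2-fold lower number from compound 2 to compound 4 (0.36 log units; beyond the scatter). Against cyclopropylsulfonyl, 4-cyanobenzyl gave a 1.0-fold higher number from compound 1 to compound 4 (0.00 log units; within the scatter), so the two groups cannot be told apart here.

Going by these compounds, compound 2 and compound 3 both stay at a limit of the assay, and the step between them cannot be read: the limit of > 40000 nM in this assay, at which 2 of the 4 values shown sit. Whether a benzyl group without the nitrile, or a longer chain ending in an amine, on this ring nitrogen would give a lower number remains open.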